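Hydrogen in place of isopropyl on the amine of compound 2

This account rests on a few compounds, and the source may have more. Where it says the series, first, only, none or still open, it means among the compounds named here.

Compound 2 `CC(C)NCCS(=O)(=O)NC(=O)c1ccc(Nc2nc(NC3(c4ccc(Cl)cc4)CC3)nc(OCC(F)(F)F)n2)cc1` gives 100% in an ADME assay on microsomes from liver (Rattus norvegicus) for metabolic stability, with a stated time of 10 min (a higher number here means that more of the compound is left, a lower number that less of the compound is left), level with compound 3 `COC(=O)NCCS(=O)(=O)NC(=O)c1ccc(Nc2nc(NC3(c4ccc(Cl)cc4)CC3)nc(OCC(F)(F)F)n2)cc1` at 100% and together with it the highest of three numbers, while compound 1 `CC(C)S(=O)(=O)NC(=O)c1ccc(Nc2nc(NC3(c4ccc(Cl)cc4)CC3)nc(OCC(F)(F)F)n2)cc1` gives 96%. Within the data shown here, the steps of a number 4 percentage points higher from compound 1 to compound 2 (within the scatter) and a number 4 percentage points higher from compound 1 to compound 3 (within the scatter) are both within the scatter, and no change at the digits printed from compound 2 to compound 3 (within the scatter), the only step on the same amine nitrogen, a swap of methoxycarbonyl for isopropyl, is also within the scatter. Compound 4 `NCCS(=O)(=O)NC(=O)c1ccc(Nc2nc(NC3(c4ccc(Cl)cc4)CC3)nc(OCC(F)(F)F)n2)cc1` differs from compound 2 by hydrogen in place of isopropyl on an amine nitrogen. With every measured step within the scatter and all three numbers near the top of the scale, compound 4 is expected to stay at the high end: the estimate is 98%, within 88% to 100%, a step of a number 2 percentage points lower from compound 2 to compound 4 (within the scatter) not beyond the scatter.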

Compound 4, percent of the compound remaining: 100%
The estimate for compound 4 lay 2 percentage points below the measured number; the range from low to high includes it.
By their numbers in this assay, from the lowest: compounds 1, 2, 3 and 4 (each within the scatter of the next).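

In this assay the amine nitrogen now holds hydrogen as well as isopropyl or methoxycarbonyl without separating the compounds, with no change at the digits printed from compound 2 to compound 4 (within the scatter) and no change at the digits printed from compound 3 to compound 4 (within the scatter) as the two steps on that nitrogen. The unsubstituted 2-aminoethyl on the sulfonyl sulfur also stays within the scatter of isopropyl, with a number 4 percentage points higher from compound 1 to compound 4 (within the scatter) as its step. Nothing on hand explains these readings. Open, from the compounds shown here alone, is whether a carboxylic acid at the end of the chain, or a longer chain carrying the amine, would leave this reading unchanged.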